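Shifting the Nitro Group on the Phenyl Ring

The compounds below may be only part of what the source reports. "The series", "measured", "known", "first", "only" and "open" are said of these compounds alone.

Of the compounds shown here, two have been measured so far in a functional assay on HEK293 cells for agonist activity at Free fatty acid receptor 1 (Homo sapiens), read by fluorescence and calcium flux; on this read-out lower numbers stand for an effect already at smaller amounts and higher numbers for an effect only at larger amounts of compound. Compound 1 `CC#CC(CC(=O)O)c1ccc(OCc2ccc(C(=O)N3CCN(Cc4ccccc4)CC3)s2)cc1` gives 155 nM. Among the measured compounds shown here, compound 2 `CC#CC(CC(=O)O)c1ccc(OCc2ccc(C(=O)N3CCN(c4ccc([N+](=O)[O-])cc4)CC3)s2)cc1` gives 231 nM, the higher of the two numbers, and its only neighbour is compound 1, reached through the step of a 1.5-fold higher number from compound 1 to compound 2 (0.17 log units; within the scatter), which is within the scatter. Compound 3 `CC#CC(CC(=O)O)c1ccc(OCc2ccc(C(=O)N3CCN(c4cccc([N+](=O)[O-])c4)CC3)s2)cc1` has not yet been measured; it differs from compound 2 by 3-nitrophenyl in place of 4-nitrophenyl on an amine nitrogen in a ring. For the measured compounds named here, no measured step exchanges one nitrophenyl for another, so the change is not directly covered; the one step that does touch this ring nitrogen, from benzyl to 4-nitrophenyl, stayed within the scatter. On that basis no step beyond the scatter is expected in this assay, in either direction. Compound 3 is therefore estimated at 230 nM, with a range from 100 nM to 550 nM. This expectation corresponds to a step of a 1.0-fold lower number from compound 2 to compound 3 (0.00 log units; within the scatter).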

Compound 3, half-maximal effective concentration: 187 nM
For compound 3 the middle estimate is 1.2-fold (0.09 log units) above the measured one; the measured number falls inside the stated range.
By their numbers in this assay, from the lowest: compounds 1, 3 and 2 (each within the scatter of the next).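

Moving the nitro group, with 3-nitrophenyl in place of 4-nitrophenyl on the amine nitrogen in the ring, gives a small change in this assay (a 1.2-fold lower number from compound 2 to compound 3 (0.09 log units; within the scatter)). Among the compounds shown here, this is the first direct exchange of one nitrophenyl for the other, and across these two compounds the placement of the nitro group makes no difference that can be told from the scatter. The 3-nitrophenyl group also reads close to benzyl (a 1.2-fold higher number from compound 1 to compound 3 (0.08 log units; within the scatter)), so all three groups on this nitrogen now stand within the scatter of one another, and no measurement at hand speaks to what lies behind this.

Still open, on these data alone, is whether a phenyl ring carrying an amine or a carboxylic acid in place of the nitro group would stay in this range. Also open, as far as these compounds go, is whether a longer chain between the ring nitrogen and the phenyl ring would do so.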